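Chloro on the phenyl of compound 3

The source may report more compounds than this note shows. Statements on the series, on what has been measured and on what is new or still open speak of the compounds shown alone.

Values in a functional assay on SEM cells (Homo sapiens) for cytotoxicity, with a stated time of 72 h (on this read-out higher numbers stand for an effect only at larger amounts of compound and lower numbers for an effect already at smaller amounts), follow
compound 1 (`C=C[C@](C)(CCCC(C)C)CCc1ccc(O)cc1`) gives > 36600 nM
compound 2 (`C=C[C@@](C)(/C=C/c1ccc(O)cc1)CC/C=C(\C)CO`) gives > 36600 nM
compound 3 (`CC(C)=CCC[C@@](C)(/C=C/c1ccccc1)/C=C/c1ccc(O)cc1`) gives > 36600 nM

Compound 3 stands at > 36600 nM as a limit of the assay and not a number. The set as a whole shows the limit of > 36600 nM in this assay, at which 3 of the 3 values shown sit, and offers no graded value. Compound 4 (`CC(C)=CCC[C@](C)(/C=C/c1ccc(O)cc1)/C=C/c1cccc(Cl)c1`) turns the phenyl of compound 3 into 3-chlorophenyl, with chloro in place of hydrogen on an aromatic carbon. No measured step sizes this change. The estimate means an at least 1.2-fold lower number from compound 3 to compound 4 (0.08 log units; that floor lies within the scatter) as an expected small move toward lower numbers, possibly none beyond the scatter. For compound 4 the estimated value is 30000 nM with an expected range from 10000 nM to 50000 nM and a good chance of another limit reading.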

Compound 4, half-maximal effective concentration: > 36600 nM
Compound 4: only a limit was reported; the forecaster's own chance of this, stated with the estimate: 65%; at least 1.2-fold (0.08 log units) between middle value and limit.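

Compound 3 and compound 4 both sit at a limit of the assay, so no step between them can be read: the limit of > 36600 nM in this assay, at which 4 of the 4 values shown sit.

The compounds shown leave open whether chloro in place of hydrogen has any effect, and whether any member of this series gives a graded value.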